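Methyl on the Ring Nitrogen: An Expected Weak Effect

The source may report more compounds than this note shows. Statements on the series, on what has been measured and on what is new or still open speak of the compounds shown alone.

Measured compounds:
compound 1, `O=C(Cc1cccnc1)c1cc2ccccc2[nH]1`: 65000 nM
compound 2, `COc1ccc2[nH]c(C(=O)Cc3cccnc3)cc2c1`: 49000 nM

Both were tested in an assay on isolated protein for inhibition of Indoleamine 2,3-dioxygenase 1 (Homo sapiens), read by spectrophotometry; on this read-out lower numbers stand for stronger inhibition and higher numbers for weaker inhibition. Going by the values given here, compound 1 gives the highest of the two numbers, and compound 2 sits close to it: the single measured step is a 1.3-fold lower number from compound 1 to compound 2 (0.12 log units; within the scatter), brought about by methoxy in place of hydrogen on an aromatic carbon.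

Compound 3, `Cn1c(C(=O)Cc2cccnc2)cc2ccccc21`, differs from compound 1 by methyl in place of hydrogen on an aromatic nitrogen. Among the compounds with values here, no measured step touches the ring nitrogen, so the methoxy step gives no direct guide, and with only weak inhibition seen so far nothing points to a large change. Compound 3 is expected to show a 1.2-fold higher number from compound 1 to compound 3 (0.09 log units; within the scatter), an estimate of 80000 nM with a range of 30000 nM to 250000 nM.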

Compound 3, half-maximal inhibitory concentration: 34000 nM
Estimate against measurement, compound 3: 2.4-fold (0.37 log units) above; the measured number falls inside the stated range.
By their numbers in this assay, from the lowest: compounds 3, 2 and 1 (each within the scatter of the next).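

Replacing the hydrogen on the aromatic nitrogen with methyl gives a 1.9-fold lower number from compound 1 to compound 3 (0.28 log units; within the scatter). This position therefore accepts methyl in place of its hydrogen without a change beyond the scatter, and inhibition stays weak. Nothing available here explains this outcome.

From the compounds shown here alone, it remains open whether a longer chain, an amine or a carboxylic acid on this nitrogen would leave the number just as unchanged. Going by these compounds, it is also open whether methyl on the nitrogen and methoxy on the aromatic carbon would together shift it beyond the scatter.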